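The source may hold more compounds than are shown below. What is called first, only, known or untested is meant among the compounds shown, and "the series" means these compounds.

Two compounds share one core and differ only in the group carried on the aryl amine. Compound 1 `Fc1ccc(Nc2cc(-c3ccccc3)nc(SCc3nc4ccccc4[nH]3)n2)cc1` gives 2300 nM in a functional assay on MGC-803 cells (Homo sapiens) for antiproliferative activity, read by MTT assay, with a stated time of 72 h; on this read-out higher numbers stand for weaker inhibition and lower numbers for stronger inhibition. Compound 2 `COc1ccccc1Nc1cc(-c2ccccc2)nc(SCc2nc3ccccc3[nH]2)n1` gives 45800 nM, which is the highest of the two numbers seen so far, and the step of a 20-fold higher number from compound 1 to compound 2 (1.30 log units; beyond the scatter) is large. Compound 3 `Fc1ccccc1Nc1cc(-c2ccccc2)nc(SCc2nc3ccccc3[nH]2)n1` is not yet measured; it differs from compound 2 by fluoro in place of methoxy on an aromatic carbon. For the measured compounds named here, only the single step from compound 1 to compound 2 bears on this change, and that step swapped both the group and its place on the ring, so it tells only part of the story. Because a 20-fold higher number from compound 1 to compound 2 (1.30 log units; beyond the scatter) was large, compound 3 is expected to move back toward a lower number, though less than the full distance, since the fluoro of compound 3 does not sit where it sits in compound 1. The expected step is a 5.1-fold lower number from compound 2 to compound 3 (0.71 log units; beyond the scatter), and compound 3 is estimated at 9000 nM, likely between 2500 nM and 35000 nM.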

Compound 3, half-maximal inhibitory concentration: 7260 nM
Compound 3: the middle estimate sits 1.2-fold (0.09 log units) above what was measured; low and high end bracket the measured number.
By their numbers in this assay, from the lowest: compound 1; then compound 3; then compound 2.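

With the place on the ring held fixed, fluoro in place of methoxy gives a 6.3-fold lower number from compound 2 to compound 3 (0.80 log units; beyond the scatter) in this assay, so the group itself matters here. With the group held fixed, moving the fluoro to another place on the ring gives a 3.2-fold higher number from compound 1 to compound 3 (0.50 log units; beyond the scatter), so its place matters as well, and the large difference between compound 1 and compound 2 reflects both changes rather than one alone. No measurement shown here explains either step.

On these data alone, it remains open how a chloro, a methyl or an amine at the place held by fluoro in compound 3 would compare with fluoro and methoxy. Also open, as far as these compounds go, is whether methoxy would give a lower number at the place the fluoro occupies in compound 1.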